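Replacing the Cyanobenzyl Arm with an Ethyl Ester Chain

The compounds below may be only part of what the source reports. "The series", "measured", "known", "first", "only" and "open" are said of these compounds alone.

Of the compounds shown here, three built on one shared core have been measured in an ADME assay on L02 cells (Homo sapiens) for cytotoxicity, read by MTT assay, with a stated time of 48 h; a lower number here means a stronger inhibitor, a higher number a weaker inhibitor. Compound 3 `CCN(CC)c1ccc2cc(C(=O)c3ccc(N4CCN(C(=O)CN5CCN(Cc6ccc(C#N)cc6)CC5)CC4)cc3)oc2c1` gives 29600 nM, the highest number of the three. Compound 1 `CCN(CC)c1ccc2cc(C(=O)c3ccc(N4CCN(C(=O)CN5CCN(Cc6ccc(F)c(F)c6)CC5)CC4)cc3)oc2c1` gives 10200 nM, and compound 2 `CCN(CC)c1ccc2cc(C(=O)c3ccc(N4CCN(C(=O)CN5CCN(Cc6ccc(C(F)(F)F)cc6)CC5)CC4)cc3)oc2c1` gives 6540 nM. Both steps that end at compound 3, a 2.9-fold higher number from compound 1 to compound 3 (0.46 log units; beyond the scatter) and a 4.5-fold higher number from compound 2 to compound 3 (0.66 log units; beyond the scatter), lie beyond the scatter, whereas a 1.6-fold lower number from compound 1 to compound 2 (0.19 log units; within the scatter) does not.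

Compound 4 `CCOC(=O)CN1CCN(CC(=O)N2CCN(c3ccc(C(=O)c4cc5ccc(N(CC)CC)cc5o4)cc3)CC2)CC1` has not yet been measured. Relative to compound 3 the change is ethoxycarbonyl in place of 4-cyanophenyl on a saturated chain carbon bound to an amine nitrogen in a ring. Within the data shown here, both measured steps reaching compound 3 only exchange one substituent on the aromatic ring at this position and were modest in size; no measured step removes that ring altogether, so they serve only as a rough guide to the scale of variation at this place. A modest step in this assay is therefore expected, its direction uncertain, and the estimate corresponds to a 1.2-fold lower number from compound 3 to compound 4 (0.07 log units; within the scatter). Compound 4 is expected to give about 25000 nM, within a range from 8000 nM to 80000 nM.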

Compound 4, half-maximal inhibitory concentration: 68700 nM
The estimate for compound 4 lay 2.7-fold (0.44 log units) below the measured number; the measured number falls inside the stated range.
By their numbers in this assay, from the lowest: compounds 2 and 1 (each within the scatter of the next); then compound 3; then compound 4.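

Taking the aromatic ring off this position, a saturated chain carbon bound to an amine nitrogen in a ring, raises the number in this assay in all three comparisons: a 2.3-fold higher number from compound 3 to compound 4 (0.37 log units; beyond the scatter), a 6.7-fold higher number from compound 1 to compound 4 (0.83 log units; beyond the scatter) and an 11-fold higher number from compound 2 to compound 4 (1.02 log units; beyond the scatter), the last of these large. Compounds 1, 2 and 3, which all keep a substituted benzyl arm, give lower numbers than compound 4, so exchanging the whole arm can move the number further than any of the measured exchanges of a substituent on the ring. No measurement is available that explains this rise.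

Compound 4 loses the ring and gains the ester in a single change, so the compounds shown cannot separate the two. An unsubstituted benzyl arm, a carboxylic acid in place of the ethyl ester, or a plain alkyl chain at this place would help to tell them apart.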